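From 4-chlorophenyl to 2,4-difluorophenyl in growth inhibition

The source may hold more compounds than are shown below. What is called first, only, known or untested is meant among the compounds shown, and "the series" means these compounds.

Of the compounds shown here, three with a shared core have been tested in a functional assay on UACC-62 cells (Homo sapiens); a lower number here means a stronger inhibitor of growth, a higher number a weaker inhibitor of growth. For the measured compounds named here, compound 3 `O=S(=O)(/C=C/c1ccc(Cl)cc1)Cc1ccc(Nc2ncnc3ccccc23)cc1`, which carries a 4-chlorophenyl group, gives 13000 nM, the only actual number in the set. Compound 1 `O=S(=O)(/C=C/c1ccccc1)Cc1ccc(Nc2ncnc3ccccc23)cc1` gives > 100000 nM, which is a limit of the assay. Compound 2 `O=S(=O)(/C=C/c1ccc(Br)cc1)Cc1ccc(Nc2ncnc3ccccc23)cc1` gives > 100000 nM, which is also a limit of the assay.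

Compound 4 `O=S(=O)(/C=C/c1ccc(F)cc1F)Cc1ccc(Nc2ncnc3ccccc23)cc1` is still to be measured. Its difference from compound 3 is 2,4-difluorophenyl in place of 4-chlorophenyl on a double-bonded chain carbon bound to a double-bonded chain carbon.

Going by the values given here, two measured steps bear on this change. Gaining a chloro group gave an at least 7.6-fold lower number from compound 1 to compound 3 (0.88 log units; beyond the scatter), and swapping bromo for chloro gave an at least 7.6-fold lower number from compound 2 to compound 3 (0.88 log units; beyond the scatter). The remaining comparison is a step that the two limits leave unreadable from compound 1 to compound 2. Among the compounds with values here, no measured compound carries fluoro. Compound 4 has no chloro either, so a higher number is expected, reading an at least 7.6-fold lower number from compound 1 to compound 3 (0.88 log units; beyond the scatter) backwards, and a modest step seems likely, though a reading at the limit of the assay is quite possible. The estimated change is a 2.7-fold higher number from compound 3 to compound 4 (0.43 log units; beyond the scatter). For compound 4 the expected value is 35000 nM, with an estimated range from 9000 nM to 100000 nM.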

Compound 4, concentration for 50% growth inhibition: > 100000 nM
Compound 4 gave a limit, no number; the forecaster's own chance of this, stated with the estimate: 40%; middle value at least 2.8-fold (0.45 log units) away from the limit.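

In this assay, putting 2,4-difluorophenyl in place of 4-chlorophenyl on a double-bonded chain carbon bound to a double-bonded chain carbon gave an at least 7.6-fold higher number from compound 3 to compound 4 (0.88 log units; beyond the scatter). Compound 3 now stands apart, by steps beyond the scatter, from all three other compounds, so the effect seen earlier with 4-chlorophenyl is not shared by either of the other halogen-bearing groups, 4-bromophenyl and 2,4-difluorophenyl. The result for compound 4 is a limit of the assay and not a number, so the steps among compounds 1, 2 and 4 cannot be read, and it adds to a cluster of such results: the limit of > 100000 nM in this assay, at which 3 of the 4 values shown sit.

This change removes the chloro group and brings in two fluoro groups in a single move, so the compounds shown cannot say whether the loss goes with losing chloro or with gaining fluoro, nor how far above the limit any of these three compounds lies. Going by these compounds, how a phenyl ring carrying a methoxy group, a nitrile or a methyl group would read in this assay also remains open.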